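A few compounds are considered here, and "the series" means these few. Any claim that something is new, unique, unknown or untested is made for them only; others in the source may bear on it.

Compound 2 `CCCCNC(=N)N1C[C@H](O)[C@@H](O)[C@H](O)[C@H]1CO` is the urea-to-guanidine partner of compound 1 `CCCCNC(=O)N1C[C@H](O)[C@@H](O)[C@H](O)[C@H]1CO` on the shared core. In an assay for inhibition of beta-galactosidase (Bos taurus), read by spectrophotometry, with a stated time of 30 min (a lower number here means a stronger inhibitor, a higher number a weaker inhibitor), compound 2 gives 15000 nM, and compound 1 gives 27000 nM; the two sit within the scatter of each other, so compound 2 stands at one of only two numbers shown. Compound 3 `N=C(NCCOCCO)N1C[C@H](O)[C@@H](O)[C@H](O)[C@H]1CO` reaches only the limit > 1000000 nM in this assay. From the compounds shown here alone, the step of an at least 66-fold higher number from compound 2 to compound 3 (1.82 log units; beyond the scatter) therefore rests on a limit, (the limit of > 1000000 nM in this assay, at which 1 of the 3 values shown sits), and its true size is unknown beyond the lower bound.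

Compound 4 `N=C(NCCO)N1C[C@H](O)[C@@H](O)[C@H](O)[C@H]1CO` differs from compound 2 by hydroxy in place of ethyl on a saturated chain carbon, two bonds along the chain from an amine nitrogen. For the measured compounds named here, the only measured step at this position is that from compound 2 to compound 3, a loss that is large even as a bound; the change to compound 4 is a smaller cut at the same carbon, so a loss in this assay is expected, though likely smaller than the bound seen. Compound 4 is expected to give about 150000 nM in this assay, within 30000 nM to 1000000 nM. The expected step of a 10-fold higher number from compound 2 to compound 4 (1.00 log units; beyond the scatter) is thus a weakening, with a real chance that compound 4 is reported only as a limit.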

Compound 4, half-maximal inhibitory concentration: > 1000000 nM
Compound 4 gave a limit, no number; the forecaster's own chance of this, stated with the estimate: 35%; middle value at least 6.6-fold (0.82 log units) away from the limit.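

The step of an at least 66-fold higher number from compound 2 to compound 4 (1.82 log units; beyond the scatter) shows that the loss at this carbon does not depend on the longer 2-hydroxyethoxy group, since the smaller hydroxy in place of ethyl also ends at the limit. The step between compound 3 and compound 4 cannot be read, so no order can be given between these two chains, and both hydroxy-ended chains on the guanidine now share one limit, not a number: the limit of > 1000000 nM in this assay, at which 2 of the 4 values shown sit.

Among the guanidines shown, compound 2 alone carries a plain butyl chain, so it stays open whether the loss follows the terminal hydroxy or the change in the chain as a whole. A hexyl chain, or an amine or a carboxylic acid at the chain end, would test how narrow the requirement at this carbon is in this assay.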